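Swapping Bromophenyl for Dichlorophenyl in a Cytotoxicity Series

The compounds below may be only part of what the source reports. "The series", "measured", "known", "first", "only" and "open" are said of these compounds alone.

Compound 1 `Cc1c(O)c(=O)ccn1CC(=O)N/N=C1\C(=O)N(CC(=O)Nc2ccc(Br)cc2)c2ccccc21` gives 29300 nM in a functional assay on A549 cells (Homo sapiens) for cytotoxicity, read by MTT assay, with a stated time of 48 h; a lower number here means that less compound is needed, a higher number that more compound is needed for the effect.
Compound 2 `Cc1c(O)c(=O)ccn1CC(=O)N/N=C1\C(=O)N(CC(=O)Nc2ccccc2)c2ccccc21` gives 29200 nM.
Compound 3 `CC(=O)Nc1ccc(NC(=O)CN2C(=O)/C(=N\NC(=O)Cn3ccc(=O)c(O)c3C)c3ccccc32)cc1` reaches only the assay's limit, > 100000 nM.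

Compound 1 stands with compound 2 inside the scatter of a single value, a 1.0-fold lower number from compound 1 to compound 2 (0.00 log units; within the scatter), while the remaining value is a limit. Compound 4 `Cc1c(O)c(=O)ccn1CC(=O)N/N=C1\C(=O)N(CC(=O)Nc2cc(Cl)cc(Cl)c2)c2ccccc21` differs from compound 1 in one place (3,5-dichlorophenyl in place of 4-bromophenyl on an amide-type nitrogen). Going by the values given here, two measured steps bear on this: exchanging bromo for hydrogen, a 1.0-fold lower number from compound 1 to compound 2 (0.00 log units; within the scatter), and exchanging bromo for acetamido, an at least 3.4-fold higher number from compound 1 to compound 3 (0.53 log units; beyond the scatter). Compound 4 keeps halogens rather than adding an acetamido group, so the closer precedent is a 1.0-fold lower number from compound 1 to compound 2 (0.00 log units; within the scatter), and no step beyond the scatter is expected: a 1.2-fold lower number from compound 1 to compound 4 (0.07 log units; within the scatter). The estimate for compound 4 is 25000 nM, expected to fall between 8000 nM and 80000 nM.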

Compound 4, half-maximal effective concentration: 22100 nM
The estimate for compound 4 lay 1.1-fold (0.05 log units) above the measured number, within the range that was stated.
By their numbers in this assay, from the lowest: compounds 4, 2 and 1 (each within the scatter of the next). At a limit, above all of these: compound 3.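

In this assay, 3,5-dichlorophenyl on the amide-type nitrogen stays level with both 4-bromophenyl (a 1.3-fold lower number from compound 1 to compound 4 (0.12 log units; within the scatter)) and plain phenyl (a 1.3-fold lower number from compound 2 to compound 4 (0.12 log units; within the scatter)), so this position shows no change among these three rings even with two chlorines on the ring. Only 4-acetamidophenyl goes against this, and the step to the dichlorophenyl ring lies beyond the scatter (an at least 4.5-fold lower number from compound 3 to compound 4 (0.65 log units; beyond the scatter)). The value for compound 3 is a limit, so that step has no upper end: the limit of > 100000 nM in this assay, at which 1 of the 4 values shown sits.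

From the compounds shown here alone, it remains open how an amine or a carboxylic acid on this ring would read. Also open, going by these compounds, is whether a longer chain at this position could bring the number clearly lower.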